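Hydroxyl and bromine on the aryl hydrazone of compound 3

The source may report more compounds than this note shows. Statements on the series, on what has been measured and on what is new or still open speak of the compounds shown alone.

Compound 3 `COc1cc2ncnc(Nc3ccc(F)c(Cl)c3)c2cc1NC(=O)N/N=C/c1ccc(F)cc1` stands at the top of the three numbers measured in a functional assay on PC-3 cells (Homo sapiens) for cytotoxicity, read by MTT assay, with a stated time of 72 h; on this read-out higher numbers stand for weaker inhibition and lower numbers for stronger inhibition: compound 3 gives 36500 nM, while compound 1 `COc1ccc(/C=N/NC(=O)Nc2cc3c(Nc4ccc(F)c(Cl)c4)ncnc3cc2O[C@H]2CCOC2)c(OC)c1OC` gives 25600 nM and compound 2 `CCN(CC)c1ccc(/C=N/NC(=O)Nc2cc3c(Nc4ccc(F)c(Cl)c4)ncnc3cc2O[C@H]2CCOC2)c(O)c1` gives 4590 nM. The gap from compound 3 to compound 1 lies within the scatter, and only compound 2 sits clearly apart.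

Compound 4 `COc1cc2ncnc(Nc3ccc(F)c(Cl)c3)c2cc1NC(=O)N/N=C/c1ccc(O)c(Br)c1` has not yet been measured in this assay. It differs from compound 3 in one place: 3-bromo-4-hydroxyphenyl in place of 4-fluorophenyl on a carbon with a double bond to nitrogen.

Among the compounds with values here, one measured step bears on this change, though loosely. The step of a 5.6-fold lower number from compound 1 to compound 2 (0.75 log units; beyond the scatter) also swapped the aryl group on the carbon with a double bond to nitrogen, and the group that entered there likewise carried a hydroxyl. That step was modest yet beyond the scatter, and it was made on a core that is not the core of compound 3. An aryl group with a hydroxyl has so far gone with a lower number, so a lower number is expected for compound 4, but only a small step of a 2.3-fold lower number from compound 3 to compound 4 (0.36 log units; beyond the scatter) is anticipated, one that may well stay within the scatter.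

Compound 4 is therefore estimated at 16000 nM, with a range from 6000 nM to 40000 nM.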

Compound 4, half-maximal inhibitory concentration: 15300 nM
The estimate for compound 4 lay 1.0-fold (0.02 log units) above the measured number, and the stated range covers the measured number.
By their numbers in this assay, from the lowest: compound 2; then compounds 4, 1 and 3 (each within the scatter of the next, the first and the last beyond it).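

On the core of compound 3, the aryl group on the carbon with a double bond to nitrogen matters in this assay: 3-bromo-4-hydroxyphenyl in place of 4-fluorophenyl gives a 2.4-fold lower number from compound 3 to compound 4 (0.38 log units; beyond the scatter). Until now, the only step at this position beyond the scatter was on a different core, so the position is now shown to respond on both cores, although this step is modest and, within the scatter of compound 1, compound 4 still gives 15300 nM. The change removes a fluorine and brings in a hydroxyl and a bromine at once, so the step cannot be divided among them, and nothing available accounts for it.

The compounds shown leave open whether an aryl group with the hydroxyl alone or the bromine alone would reproduce this step, and whether an amine or a carboxylic acid in place of the hydroxyl would do the same. They also leave open whether the 4-(diethylamino)-2-hydroxyphenyl group of compound 2 would give a lower number on the core of compound 3.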